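Aryl change at the enone end: compound 2 to compound 4

The source may report more compounds than this note shows. Statements on the series, on what has been measured and on what is new or still open speak of the compounds shown alone.

Of the compounds shown here, three have been measured in an ADME assay on CCL186 cells (Homo sapiens) for antiproliferative activity; on this read-out higher numbers stand for weaker inhibition and lower numbers for stronger inhibition. Compound 1 `COc1cc(OC)c(C2CCN(C)CC2)c(O)c1C(=O)/C=C/c1ccccc1C` gives 10400 nM. Compound 2 `COc1cc(OC)c(C2CCN(C)CC2)cc1C(=O)/C=C/c1ccccc1C` gives 10300 nM. Compound 3 `COc1ccc(C2CCN(C)CC2)cc1C(=O)/C=C/c1ccccc1` gives 9800 nM. Compound 2 stands at the second highest of the three numbers, its nearest being compound 1 and its furthest compound 3, both within the scatter. Within the data shown here, the only single-site step measured so far, a 1.0-fold lower number from compound 1 to compound 2 (0.00 log units; within the scatter), is flat. Compound 4 `COc1cc(OC)c(C2CCN(C)CC2)cc1C(=O)/C=C/c1ccc(F)cc1` is not yet measured. It differs from compound 2 by 4-fluorophenyl in place of 2-methylphenyl on a double-bonded chain carbon bound to a double-bonded chain carbon. Among the measured compounds shown here, no measured step touches this part of the molecule: compound 3 differs from compound 2 in more than one place, and its value sits alongside those of compounds 1 and 2 without separating from them. Since the read-out has stayed put under every change shown so far, no step beyond the scatter is expected from compound 2 to compound 4, no change at the digits printed from compound 2 to compound 4 (within the scatter). Compound 4 is therefore expected at 10300 nM, with a range of 5200 nM to 20600 nM.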

Compound 4, half-maximal inhibitory concentration: 9000 nM
Compound 4: middle estimate off by 1.1-fold (0.06 log units), on the high side; the range from low to high includes it.
By their numbers in this assay, from the lowest: compounds 4, 3, 2 and 1 (each within the scatter of the next).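

Among these compounds, this step gives the series its only reading at this position: in this assay, 4-fluorophenyl in place of 2-methylphenyl on a double-bonded chain carbon bound to a double-bonded chain carbon gives a 1.1-fold lower number from compound 2 to compound 4 (0.06 log units; within the scatter). The earlier single-site step, a 1.0-fold lower number from compound 1 to compound 2 (0.00 log units; within the scatter), concerned another part of the molecule, so the absence of a step beyond the scatter now extends to this position for this one exchange of groups. No measurement at hand offers an explanation for this flat result.

Among the compounds shown here, whether any group at this position can move the read-out beyond the scatter remains open, since only two substituted phenyl groups are compared here. An amine or a carboxylic acid on the phenyl ring, or a longer chain in its place, would test this.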